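Amide nitrogen substituent change and cytotoxicity notes

The source may report more compounds than this note shows. Statements on the series, on what has been measured and on what is new or still open speak of the compounds shown alone.

The shared core is seen in compound 1 `O=C(NCC1CCCCC1)c1cccc(/C=C2\CC(=O)N(c3ccccc3)C2=O)c1`. In an ADME assay on NCM460 cells (Homo sapiens) for cytotoxicity, read by MTT assay, with a stated time of 72 h (a lower number here means a stronger inhibitor, a higher number a weaker inhibitor), compound 1 gives > 100000 nM, which is a limit of the assay and not a number. Compound 2 `CCCCCN1C(=O)C/C(=C\c2cccc(C(=O)NCCCC)c2)C1=O` gives > 100000 nM in this assay, again a limit. Compound 3 `CCCCCN1C(=O)C/C(=C\c2cccc(C(=O)Nc3cccc(CC)c3)c2)C1=O` gives > 100000 nM, also a limit. The step that the two limits leave unreadable from compound 2 to compound 3 cannot be sized from two limits; what the three measured compounds have in common is the limit of > 100000 nM in this assay, at which 3 of the 3 values shown sit. Within the data shown here, compound 1 therefore stands at that limit together with compound 2 and compound 3, and no measured step in the set is readable.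

Compound 4 `Cc1ccc(NC(=O)c2cccc(/C=C3\CC(=O)N(c4ccccc4)C3=O)c2)cc1C` is not yet measured. It differs from compound 1 as follows: 3,4-dimethylphenyl in place of cyclohexylmethyl on an amide-type nitrogen. Among the measured compounds shown here, the one measured step, from compound 2 to compound 3, also puts an aromatic ring in place of a chain on an amide-type nitrogen, and it left both compounds at the limit. No step beyond the scatter is expected in this assay. Compound 4 is expected to give about 100000 nM, within 50000 nM to 300000 nM, most likely reported again only as a limit. The expected step is a number no higher from compound 1 to compound 4 (the limit leaves the size open).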

Compound 4, half-maximal inhibitory concentration: > 100000 nM
Compound 4 gave a limit, no number; the forecaster's own chance of this, stated with the estimate: 85%; the middle value sits exactly at the limit.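

Compound 1 and compound 4 yield no readable new step in this assay, since each stands at a limit and not at a number: the limit of > 100000 nM in this assay, at which 4 of the 4 values shown sit.

The compounds shown leave open whether this assay would return a number for any substituent on the amide-type nitrogen, and how far each compound lies past the limit.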